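The compounds below may be only part of what the source reports. "The series", "measured", "known", "first", "only" and "open" are said of these compounds alone.

Measured compounds:
Compound 1 `c1ccc(-n2cnc3cc4c(cc32)C2CNCC4C2)cc1` — 0.14 nM
Compound 2 `Cn1cnc2cc3c(cc21)C1CNCC3C1` — 0.75 nM
Compound 3 `CCCCn1cnc2cc3c(cc21)C1CNCC3C1` — 0.2 nM

In an assay on HEK293 cells for binding affinity to Neuronal acetylcholine receptor; alpha4/beta2 (Homo sapiens) (on this read-out higher numbers stand for weaker inhibition and lower numbers for stronger inhibition), compound 3 gives 0.2 nM, the second highest of the three numbers. Compound 1 stands nearest to it, as seen in a 1.4-fold higher number from compound 1 to compound 3 (0.15 log units; within the scatter), while compound 2 stands furthest, as seen in a 3.8-fold lower number from compound 2 to compound 3 (0.57 log units; beyond the scatter).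

Compound 4 `CCCn1cnc2cc3c(cc21)C1CNCC3C1` differs from compound 3 by hydrogen in place of methyl on a saturated chain carbon, three bonds along the chain from an aromatic nitrogen. The step that bears most directly on this is a 3.8-fold lower number from compound 2 to compound 3 (0.57 log units; beyond the scatter), where the whole propyl chain was added in a single step and the number fell modestly. The step of a 5.4-fold higher number from compound 1 to compound 2 (0.73 log units; beyond the scatter) and the step of a 1.4-fold higher number from compound 1 to compound 3 (0.15 log units; within the scatter) show that the methyl compound sits apart from the phenyl and butyl compounds, which are close to each other. Removing only the terminal methyl from the butyl chain is a fraction of the change seen in the step from compound 2 to compound 3, so the expected step is small and toward a slightly higher number, probably within the scatter: a 1.5-fold higher number from compound 3 to compound 4 (0.18 log units; within the scatter). Compound 4 is therefore estimated at 0.3 nM, with a range from 0.1 nM to 0.9 nM.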

Compound 4, inhibition constant: 0.36 nM
Estimate against measurement, compound 4: 1.2-fold (0.08 log units) below, and the stated range covers the measured number.
By their numbers in this assay, from the lowest: compounds 1, 3 and 4 (each within the scatter of the next, the first and the last beyond it); then compound 2.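

In this assay, cutting the butyl chain back to propyl gives a 1.8-fold higher number from compound 3 to compound 4 (0.26 log units; within the scatter) and so leaves no difference that stands clear of the scatter. The propyl chain still holds a gain over methyl on the same aromatic nitrogen, seen in a 2.1-fold lower number from compound 2 to compound 4 (0.32 log units; beyond the scatter) as a step that is beyond the scatter, but it falls short of phenyl, with a 2.6-fold higher number from compound 1 to compound 4 (0.41 log units; beyond the scatter) as a step that is also beyond the scatter, although butyl remained within the scatter of phenyl. No measurement on hand explains these differences.

Among the three chains shown, the numbers run in order of chain length, yet the compounds leave open whether a pentyl or longer chain would extend that order or reverse it. They also leave open how a branched isopropyl group, or a benzyl group, would compare at this aromatic nitrogen.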